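Removing the chloro from compound 3

The source may report more compounds than this note shows. Statements on the series, on what has been measured and on what is new or still open speak of the compounds shown alone.

Measured so far:
compound 1, `Cc1ccc2nc(Nc3ccnc(Nc4ccc(S(C)(=O)=O)cc4)n3)sc2c1`: 4440 nM
compound 2, `CS(=O)(=O)c1ccc(Nc2ncc(F)c(Nc3nc4ccccc4s3)n2)cc1`: 4980 nM
compound 3, `CS(=O)(=O)c1ccc(Nc2nccc(Nc3nc4ccc(Cl)cc4s3)n2)cc1`: > 50000 nM

In a functional assay on MDA-MB-231 cells (Homo sapiens) for antiproliferative activity, read by MTT assay, with a stated time of 48 h (on this read-out higher numbers stand for weaker inhibition and lower numbers for stronger inhibition), compound 1 gives 4440 nM and compound 2 gives 4980 nM. The value of compound 3, > 50000 nM, is a limit of this assay and not a number (the limit of > 50000 nM in this assay, at which 1 of the 3 values shown sits). Among the three, compound 3 stands apart: the step of an at least 11-fold higher number from compound 1 to compound 3 (1.05 log units; beyond the scatter).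

Compound 4, `CS(=O)(=O)c1ccc(Nc2nccc(Nc3nc4ccccc4s3)n2)cc1`, is not yet measured. Its change from compound 3 is hydrogen in place of chloro on an aromatic carbon. Among the compounds with values here, the only measured step that touches this position is the one from compound 1 to compound 3, and it was large; removing the chloro is expected to take compound 4 back toward the range of compound 1 and compound 2. For compound 4 the expected step is an at least 8.3-fold lower number from compound 3 to compound 4 (0.92 log units; beyond the scatter), toward stronger inhibition. Compound 4 is therefore estimated at 6000 nM, within 2000 nM to 25000 nM.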

Compound 4, half-maximal inhibitory concentration: 5910 nM
For compound 4 the middle estimate is 1.0-fold (0.01 log units) above the measured one, and the stated range covers the measured number.
By their numbers in this assay, from the lowest: compounds 1, 2 and 4 (each within the scatter of the next). At a limit, above all of these: compound 3.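

In this assay, within the data shown here, the single change from chloro to hydrogen at this aromatic carbon gives an at least 8.4-fold lower number from compound 3 to compound 4 (0.92 log units; beyond the scatter), so chloro here differs sharply from both hydrogen and methyl, which are not told apart: a 1.3-fold higher number from compound 1 to compound 4 (0.12 log units; within the scatter). Hydrogen in place of fluoro, on an aromatic carbon at another place, also leaves the number within the scatter: a 1.2-fold higher number from compound 2 to compound 4 (0.07 log units; within the scatter). The value of compound 3 is a limit and not a number: the limit of > 50000 nM in this assay, at which 1 of the 4 values shown sits.

Open, from the compounds shown here alone, is whether this drop belongs to chloro alone or would also appear with bromo, methoxy or an amine on this carbon.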